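Notes on three measured analogues and one unmeasured

This account rests on a few compounds, and the source may have more. Where it says the series, first, only, none or still open, it means among the compounds named here.

Measured compounds:
compound 1 `C=CCn1c(=O)/c(=C\c2ccc(Cl)c(Cl)c2)[nH]c(=O)/c1=C\c1ccccc1`: "not active" (no number reported)
compound 2 `C=CCn1c(=O)/c(=C\c2cccc(Br)c2)[nH]c(=O)/c1=C\c1ccccc1OC`: 5200 nM
compound 3 `C=CCn1c(=O)/c(=C\c2cccc(Br)c2)[nH]c(=O)/c1=C\c1cccc(Br)c1`: "not active" (no number reported)

For the measured compounds named here, in a functional assay on HL-60 cells (Homo sapiens) for cytotoxicity, read by CCK-8 assay, with a stated time of 72 h (a lower number here means a stronger inhibitor, a higher number a weaker inhibitor), compound 2 carries the only number in the set; compound 1 and compound 3 are reported only as not active, without a number, so compound 2 cannot be ranked against them beyond that. Going by the values given here, no pair of measured compounds differing in a single place is available, so no measured step anchors the size of a change on the shared core.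

Compound 4 `C=CCn1c(=O)/c(=C\c2ccccc2C(F)(F)F)[nH]c(=O)/c1=C\c1ccccc1OC` differs from compound 2 in one place: 2-(trifluoromethyl)phenyl in place of 3-bromophenyl on a double-bonded chain carbon bound to an aromatic carbon. Among the compounds with values here, with no measured step to go by, and with two of three compounds in the set returning no number, the expectation for compound 4 is a modest weakening, possibly not beyond the usual scatter, and a real chance that this assay again reports no number. The expected step from compound 2 to compound 4 is a 1.7-fold higher number from compound 2 to compound 4 (0.24 log units; within the scatter). Compound 4 is thus estimated at 9000 nM in this assay, with a range of 2500 nM to 30000 nM.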

Compound 4, half-maximal inhibitory concentration: 4600 nM
Estimate against measurement, compound 4: 2.0-fold (0.29 log units) above; low and high end bracket the measured number.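

In this assay, the series gets its first measured single-place step, a 1.1-fold lower number from compound 2 to compound 4 (0.05 log units; within the scatter), so 2-(trifluoromethyl)phenyl and 3-bromophenyl cannot be told apart on a double-bonded chain carbon bound to an aromatic carbon. This place therefore accepts the group of 10 heavy atoms as well as the group of 7, and a measured number here is not tied to 3-bromophenyl. Nothing available bears on why the two groups read alike.

Going by these compounds, it remains open whether a phenyl group carrying an amine or a carboxylic acid at this place would still give a number in this assay. Also open, on these data alone, is whether the two groups would still read alike with a longer chain in place of the allyl group on the shared core.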